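Hydroxy on the ring carbon of compound 2

The compounds below may be only part of what the source reports. "The series", "measured", "known", "first", "only" and "open" are said of these compounds alone.

Values in a functional assay on the whole organism for activation, with Mus musculus as the target, with a stated time of 60 min; a higher number here means that more compound is needed for the effect, a lower number that less compound is needed:
- compound 1 `CC(=O)Nc1ccc(-c2ccc(/C=N/N3C(=O)NC(=O)C3O)o2)cc1`: > 1000 mg/kg (a limit)
- compound 2 `O=C1CN(/N=C/c2ccc(-c3cccc(C(F)(F)F)c3)o2)C(=O)N1`: 143 mg/kg
- compound 3 `Nc1ccc(-c2ccc(/C=N/N3C(=O)NC(=O)C3O)o2)cc1`: > 1000 mg/kg (a limit)

Among the compounds with values here, compound 2 holds the only number. Compound 1 and compound 3 both stand at the limit of > 1000 mg/kg in this assay, at which 2 of the 3 values shown sit. Compound 4 `O=C1NC(=O)N(/N=C/c2ccc(-c3cccc(C(F)(F)F)c3)o2)C1O` differs from compound 2 by hydroxy in place of hydrogen on a saturated ring carbon. Within the data shown here, the one measured step is a step that the two limits leave unreadable from compound 1 to compound 3, which gives no size and does not involve this change. Compound 1 and compound 3 share the 5-hydroxy-2,4-dioxoimidazolidin-1-yl group with compound 4 but differ elsewhere, so they offer only indirect support for a shift towards a higher dose. The expected change is a 2.4-fold higher number from compound 2 to compound 4 (0.39 log units; beyond the scatter). For compound 4 the estimated value is 350 mg/kg, with an expected range of 120 mg/kg to 1000 mg/kg.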

Compound 4, dose for half-maximal effect: 244 mg/kg
The estimate for compound 4 lay 1.4-fold (0.16 log units) above the measured number, within the range that was stated.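

In this assay, within the data shown here, the step for hydroxy in place of hydrogen on a saturated ring carbon reads a 1.7-fold higher number from compound 2 to compound 4 (0.23 log units; within the scatter) and is the first readable size at this position. Compound 4 keeps a measured number with the 5-hydroxy-2,4-dioxoimidazolidin-1-yl group, so this group does not by itself bring a compound to the limit: the limit of > 1000 mg/kg in this assay, at which 2 of the 4 values shown sit.

This rests on a single pair of compounds. From the compounds shown here alone, whether a methoxy group, an amine or a carboxylic acid on this ring carbon would give a similar number stays open.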